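A few compounds are considered here, and "the series" means these few. Any claim that something is new, unique, unknown or untested is made for them only; others in the source may bear on it.

Measured in a functional assay on MCF7 cells (Homo sapiens) for cytotoxicity, with a stated time of 48 h; a higher number here means a weaker inhibitor, a lower number a stronger inhibitor:
Compound 1 `COc1cc(O)c(C(=O)/C=C/c2ccc(F)cc2)c(OC)c1`: 8800 nM
Compound 2 `COc1cc(OC)c(C(=O)/C=C/c2ccccc2OC)c(OC)c1`: 8900 nM
Compound 3 `COc1cc(OC)c(C(=O)/C=C/c2ccccc2SC)c(OC)c1`: 9300 nM

Compound 3, at 9300 nM, lies within the scatter of the other two compounds, so the three cannot be ranked. Compound 4 `COc1cccc(/C=C/C(=O)c2c(OC)cc(OC)cc2OC)c1` has not yet been measured. It differs from compound 3 in one place: 3-methoxyphenyl in place of 2-(methylsulfanyl)phenyl on a double-bonded chain carbon bound to a double-bonded chain carbon. Among the compounds with values here, the one measured step that bears on this is a 1.0-fold higher number from compound 2 to compound 3 (0.02 log units; within the scatter), which puts methylsulfanyl in place of methoxy on an aromatic carbon. Within the data shown here, no measured step shows what moving the group around the ring does, so that part remains open. A change beyond the scatter is therefore not expected in this assay, and the estimated step is a 1.0-fold lower number from compound 3 to compound 4 (0.01 log units; within the scatter). For compound 4 the estimate is 9000 nM, with an expected range from 4000 nM to 20000 nM.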

Compound 4, half-maximal inhibitory concentration: 9400 nM
Compound 4: the middle estimate sits 1.0-fold (0.02 log units) below what was measured, within the range that was stated.
By their numbers in this assay, from the lowest: compounds 1, 2, 3 and 4 (each within the scatter of the next).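

Putting 3-methoxyphenyl in place of 2-(methylsulfanyl)phenyl on this double-bonded chain carbon gives a 1.0-fold higher number from compound 3 to compound 4 (0.00 log units; within the scatter) in this assay and putting it in place of 2-methoxyphenyl gives a 1.1-fold higher number from compound 2 to compound 4 (0.02 log units; within the scatter) as well. Within the data shown here, the second step is the first measure of moving the methoxy group around this ring, and the move stays within the scatter. No measured evidence accounts for these numbers. Still open, as far as these compounds go, is whether an amine or a carboxylic acid on this ring would give a step beyond the scatter.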